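Trimming One Methoxy Group from Compound 1

The source may report more compounds than this note shows. Statements on the series, on what has been measured and on what is new or still open speak of the compounds shown alone.

Compound 1 `COc1cc(-c2cc(/C=C/C(=O)c3ccc(N)cc3)[nH]n2)cc(OC)c1OC` holds the second highest of three numbers in a functional assay on SNB-19 cells (Homo sapiens) for inhibition, read by sulforhodamine B assay, with a stated time of 48 h (on this read-out lower numbers stand for stronger inhibition of growth and higher numbers for weaker inhibition of growth), giving 2340 nM. Compound 2 `COc1ccc(-c2cc(/C=C/C(=O)c3ccc(OC)c(OC)c3)[nH]n2)cc1` gives 1880 nM, within the scatter of compound 1. Compound 3 `COc1cc(-c2cc(/C=C/C(=O)c3ccc(Cl)c(Cl)c3)[nH]n2)cc(OC)c1OC` gives 9830 nM. Putting 3,4-dichlorophenyl in place of 4-aminophenyl on the carbonyl carbon produced a 4.2-fold higher number from compound 1 to compound 3 (0.62 log units; beyond the scatter). Compound 4 `COc1ccc(-c2cc(/C=C/C(=O)c3ccc(N)cc3)[nH]n2)cc1OC` differs from compound 1 by hydrogen in place of methoxy on an aromatic carbon. Among the measured compounds shown here, the one measured step concerns the aryl group on the carbonyl carbon and so does not bear directly on this change; no measured pair varies the methoxy count on the other aromatic ring. With nothing to lean on, the step is expected to stay within the scatter, so a 1.1-fold higher number from compound 1 to compound 4 (0.05 log units; within the scatter) is estimated to be small. Compound 4 is therefore expected to give 2600 nM, with a range from 1000 nM to 7000 nM.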

Compound 4, concentration for 50% growth inhibition: 4360 nM
For compound 4 the middle estimate is 1.7-fold (0.22 log units) below the measured one; low and high end bracket the measured number.
By their numbers in this assay, from the lowest: compounds 2, 1 and 4 (each within the scatter of the next, the first and the last beyond it); then compound 3.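

Hydrogen in place of methoxy on this aromatic carbon, ortho to a methoxy group and meta to a large group, gives a 1.9-fold higher number from compound 1 to compound 4 (0.27 log units; within the scatter) in this assay. Among the compounds shown here, this is the first measured step on this ring, and it leaves compound 1 and compound 4 within the scatter of each other, so this methoxy group is not needed to keep the number in that range. Nothing at hand accounts for the size of this step.

From the compounds shown here alone, whether a hydroxyl group or a fluorine atom on this carbon would stay within the scatter remains open. So does whether the same step holds with 3,4-dichlorophenyl on the carbonyl carbon.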